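Series notes: methyl on an aromatic nitrogen, values at limit

A few compounds are considered here, and "the series" means these few. Any claim that something is new, unique, unknown or untested is made for them only; others in the source may bear on it.

Measured in a functional assay on MCF7 cells (Homo sapiens) for antiproliferative activity, read by WST assay, with a stated time of 72 h; on this read-out higher numbers stand for weaker inhibition and lower numbers for stronger inhibition:

compound 1 `Clc1ccc(-c2noc(-c3cc4cc(Cl)ccc4[nH]3)n2)cc1`, limit only: > 50000 nM
compound 2 `Cn1c(-c2nc(-c3ccc(Cl)cc3)no2)cc2cc(Cl)ccc21`, limit only: > 50000 nM
compound 3 `COc1ccc(-c2noc(-c3cc4ccccc4[nH]3)n2)cc1`, limit only: > 50000 nM

Compound 2 differs from compound 1 by methyl in place of hydrogen on an aromatic nitrogen. The step that the two limits leave unreadable from compound 1 to compound 2 cannot be read, because of the limit of > 50000 nM in this assay, at which 3 of the 3 values shown sit. Compound 3 likewise gives only a limit in this assay, and the difference between its core and the core of compound 1 is not broken down here.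

Compound 4 `COc1ccc(-c2noc(-c3cc4ccccc4n3C)n2)cc1` is still to be measured. It differs from compound 3 by methyl in place of hydrogen on an aromatic nitrogen, the same change, in the same place, as that from compound 1 to compound 2. That earlier pair gives no readable size for the change, since both sit at the limit. Among the measured compounds shown here, with compound 3 itself at the limit, the expectation rests only on this assay reporting the limit for every compound so far. In this assay the expected step is a step that the limit leaves unreadable from compound 3 to compound 4. Compound 4 is therefore expected to give again a limit rather than a number, estimated at 80000 nM with a range from 30000 nM to 300000 nM.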

Compound 4, half-maximal inhibitory concentration: > 50000 nM
Compound 4: a limit, no number (the forecaster's own chance of this, stated with the estimate: 85%); the middle value is on the limit's open side.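

In this assay no step can be read from compound 3 to compound 4, because both give only a limit: the limit of > 50000 nM in this assay, at which 4 of the 4 values shown sit. The compounds shown leave open whether methyl in place of hydrogen on an aromatic nitrogen alters the read-out at all, and how any of these compounds would rank against another.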